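One Number and a Swapped Side Group

The compounds below may be only part of what the source reports. "The series", "measured", "known", "first", "only" and "open" are said of these compounds alone.

For the measured compounds named here, in an ADME assay on cells (spleen, Mus musculus, strain C57BL/6) for inhibition, read by flow cytometry and propidium iodide staining, with a stated time of 24 h, at 37 degrees C (on this read-out lower numbers stand for an effect already at smaller amounts and higher numbers for an effect only at larger amounts of compound), compound 1 (`O=C(O)CCCCc1cn(CC(=O)NCc2ccccc2)nn1`) gives 1080 uM, the only number available so far. Compound 2 (`O=C(Cn1cc(-c2ccccc2[N+](=O)[O-])nn1)NCc1ccccc1`) is recorded as "non-toxic" (no number reported). Compound 3 (`O=C(Cn1cc(-c2cccc(C(F)(F)F)c2)nn1)NCc1ccccc1`) is recorded as "non-toxic" (no number reported).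

Compound 4 (`COc1ccc(-c2cn(CC(=O)NCc3ccccc3)nn2)cc1`) has 4-methoxyphenyl in place of 4-carboxybutyl on an aromatic carbon. Going by the values given here, no pair of measured compounds shows what a change like this does in this assay, so the data give no direction for it. Among the compounds with values here, the only numerical anchor is compound 1 at 1080 uM, so no step beyond the usual scatter is expected. The estimated step is a 1.4-fold lower number from compound 1 to compound 4 (0.13 log units; within the scatter). For compound 4, the estimated value is 800 uM, with an expected range from 200 uM to 2500 uM.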

Compound 4, concentration for half-maximal effect: "non-toxic" (no number reported)
The entry for compound 4 holds no number; there is nothing to compare the estimate with.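

Compound 4 is recorded without a number, so no step from compound 1 to compound 4 can be read in this assay, and no measured property offers an explanation.

Going by these compounds, what putting 4-methoxyphenyl in place of 4-carboxybutyl does to the number stays open.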